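The compounds below may be only part of what the source reports. "The series", "measured", "known", "first", "only" and "open" are said of these compounds alone.

Two compounds have been run so far in an ADME assay on MCF7 cells (Homo sapiens) for cytotoxicity, read by MTT assay, with a stated time of 48 h (on this read-out higher numbers stand for weaker inhibition and lower numbers for stronger inhibition), and only one of them gives an actual number. Compound 2 `Brc1ccc(-c2csnn2)cc1` gives 68100 nM in this assay. Compound 1 `C/C(=N\NC(=O)COc1cccc2cccnc12)c1ccccc1` reaches only the upper limit of this assay, reported as > 100000 nM, which is a limit and not a measured number. So compound 2 stands as the single measured value, while the other entry sits at the limit of > 100000 nM in this assay, at which 1 of the 2 values shown sits.

Compound 3 `Clc1ccc(-c2csnn2)cc1` is built from compound 2 by a single swap: chloro in place of bromo on an aromatic carbon. Among the compounds with values here, no pair of measured compounds in this set differs in the same way, so there is no measured step to lean on for this change. Exchanging one halogen for another on the same carbon of the ring is a small edit, and the expectation is a step from compound 2 to compound 3 of a 1.1-fold higher number from compound 2 to compound 3 (0.04 log units; within the scatter) in this assay, which does not go beyond the usual scatter of repeated measurements in either direction. On that basis compound 3 is estimated to give about 75000 nM in this assay, with a plausible range from 30000 nM to 150000 nM.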

Compound 3, half-maximal inhibitory concentration: > 100000 nM
Compound 3: no number, only a limit; the forecaster's own chance of this, stated with the estimate: 35%; middle value at least 1.3-fold (0.12 log units) away from the limit.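

Within the data shown here, on the aromatic carbon para to a group of 5 heavy atoms, chloro in place of bromo gives an at least 1.4-fold higher number from compound 2 to compound 3 (0.16 log units; that floor lies within the scatter) in this assay, the first step that can be read in this set. The earlier compounds shown here offered no measured step at this position, and this one gives no sign that the swap lowers the number, though a floor of this size cannot by itself separate the two halogens. Only that floor can be read, and the real step may be small or much larger, because compound 3 gives a limit and not a number: the limit of > 100000 nM in this assay, at which 2 of the 3 values shown sit.

The compounds shown leave open how an amine, a methoxy group or a carboxylic acid on this same aromatic carbon would read in this assay, and whether any of these would bring a number well below that of the bromo compound. They also leave open how far past the limit compound 3 truly lies, so the size of this halogen swap remains unsettled.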